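Removing a methyl: what a fourth compound should show

The source may report more compounds than this note shows. Statements on the series, on what has been measured and on what is new or still open speak of the compounds shown alone.

Compound 1 `COc1cc(/C=C/C(=O)OCCCO[N+](=O)[O-])ccc1OCCCO[N+](=O)[O-]` carries a methyl on an oxygen on an aromatic ring. In a functional assay on NCI-H157 cells (Homo sapiens) for cytotoxicity, read by resazurin assay, with a stated time of 72 h (on this read-out lower numbers stand for stronger inhibition and higher numbers for weaker inhibition), compound 1 gives only a limit, > 50000 nM. Compound 3 `COc1cc(/C=C/C(=O)OCCCCCCO[N+](=O)[O-])ccc1OCCCCCCO[N+](=O)[O-]` is built on a different core; the difference between the two cores is not broken down here. In this assay compound 3 also reaches only the limit, > 50000 nM. Compound 2 `O=C(/C=C/c1ccc(OCCCCCCO[N+](=O)[O-])c(O)c1)OCCCCCCO[N+](=O)[O-]` differs from compound 3 by hydrogen in place of methyl on an oxygen on an aromatic ring. In this assay compound 2 again shows only the limit, > 50000 nM. The step that the two limits leave unreadable from compound 3 to compound 2 therefore cannot be sized. Compound 4 `O=C(/C=C/c1ccc(OCCCO[N+](=O)[O-])c(O)c1)OCCCO[N+](=O)[O-]` differs from compound 1 by the same change, (hydrogen in place of methyl on an oxygen on an aromatic ring). Because every value shown sits at the limit of > 50000 nM in this assay, at which 3 of the 3 values shown sit, compound 4 is expected to remain there, with an expected step of a number no higher from compound 1 to compound 4 (the limit leaves the size open). The estimate for compound 4 in this assay is 50000 nM, between 20000 nM and 120000 nM.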

Compound 4, half-maximal inhibitory concentration: 5710 nM
Compound 4: the middle estimate sits 8.8-fold (0.94 log units) above what was measured; the whole stated range lies above it.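

In this assay, going from methoxy to hydroxy on the core of compound 1 gives an at least 8.7-fold lower number from compound 1 to compound 4 (0.94 log units; beyond the scatter). The same change on the core of compound 3 cannot be read: compound 3 and compound 2 both give only limits. The lower number is therefore shown on one core only, and it is undecided whether the change carries over to the other, since few readable numbers are available: the limit of > 50000 nM in this assay, at which 3 of the 4 values shown sit.

From the compounds shown here alone, whether an amine or a carboxylic acid in place of the hydroxy would give a lower or a higher number stays open. So does the effect of a longer chain on the core of compound 4.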